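A few compounds are considered here, and "the series" means these few. Any claim that something is new, unique, unknown or untested is made for them only; others in the source may bear on it.

Compound 2 `CSc1ccc(F)cc1NCC1=NCCN1` gives 40.7 nM in an assay for binding affinity to Alpha-1B adrenergic receptor (Homo sapiens), read by radioligand binding (on this read-out higher numbers stand for weaker inhibition and lower numbers for stronger inhibition), the second highest of the three numbers recorded so far. Compound 3 `CSc1cc(F)ccc1NCC1=NCCN1` gives 15.1 nM, and compound 1 `CS(=O)(=O)c1ccc(F)cc1NCC1=NCCN1` gives 1320 nM. Among the measured compounds shown here, the one single-point step among the measured compounds is a 32-fold lower number from compound 1 to compound 2 (1.51 log units; beyond the scatter); it exchanges methylsulfanyl for methylsulfonyl and leaves the halogen untouched, so it bears only indirectly on the next change. Compound 4 `CSc1ccc(Cl)cc1NCC1=NCCN1` carries chloro in place of fluoro on an aromatic carbon. For the measured compounds named here, no measured step tests a halogen exchange, and the step in this assay is therefore expected to be small, probably a slightly lower number. Compound 4 is estimated at 30 nM, with a range of 8 nM to 120 nM, which corresponds to an expected 1.4-fold lower number from compound 2 to compound 4 (0.13 log units; within the scatter).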

Compound 4, inhibition constant: 69.2 nM
Beside the measured number, compound 4's estimate is 2.3-fold (0.36 log units) below it, and the stated range covers the measured number.
By their numbers in this assay, from the lowest: compound 3; then compounds 2 and 4 (each within the scatter of the next); then compound 1.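

In this assay chloro in place of fluoro on the aromatic carbon para to a methylsulfanyl group gives a 1.7-fold higher number from compound 2 to compound 4 (0.23 log units; within the scatter) and so leaves the number within the scatter at this position. The earlier compounds shown here included no halogen exchange and could not show this. Nothing measured on these compounds explains the step.

From the compounds shown here alone, whether a bromo, methoxy or amine group at this position would keep the number in the same range remains open. So does whether the same exchange would behave alike with methylsulfonyl in place of methylsulfanyl.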